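Varying the aryl group on a shared core in HeLa cells

This account rests on a few compounds, and the source may have more. Where it says the series, first, only, none or still open, it means among the compounds named here.

Measured compounds:
compound 1 `COc1ccccc1/C=c1\c(=O)[nH]/c(=C/c2cccc(Cl)c2Cl)c(=O)n1C` — 200 nM
compound 2 `C=CCn1c(=O)/c(=C\c2cc(F)ccc2C)[nH]c(=O)/c1=C\c1ccccc1OC` — 2900 nM
compound 3 `COc1ccccc1/C=c1\c(=O)[nH]/c(=C/c2ccccc2Cl)c(=O)n1C` — 300 nM

In a functional assay on HeLa cells (Homo sapiens) for cytotoxicity, read by CCK-8 assay, with a stated time of 72 h (a higher number here means a weaker inhibitor, a lower number a stronger inhibitor), compound 2 gives the highest of the three numbers, beyond the scatter from both compound 3 and compound 1. Compound 4 `C=CCn1c(=O)/c(=C\c2ccccc2C(F)(F)F)[nH]c(=O)/c1=C\c1ccccc1OC` differs from compound 2 in one place: 2-(trifluoromethyl)phenyl in place of 5-fluoro-2-methylphenyl on a double-bonded chain carbon bound to an aromatic carbon. For the measured compounds named here, no measured step covers such an aryl swap. Going by the values given here, the one measured step, a 1.5-fold higher number from compound 1 to compound 3 (0.18 log units; within the scatter), concerns a chloro group and lies within the scatter, so it gives little guidance. The shared core tolerates several aryl groups, and compound 1 and compound 3 show that stronger numbers are possible. Compound 4 is therefore expected to move modestly, a 1.9-fold lower number from compound 2 to compound 4 (0.29 log units; within the scatter), with wide uncertainty. Compound 4 is estimated at 1500 nM, between 400 nM and 6000 nM.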

Compound 4, half-maximal inhibitory concentration: 4600 nM
The estimate for compound 4 lay 3.1-fold (0.49 log units) below the measured number; measured number inside the range.
By their numbers in this assay, from the lowest: compounds 1 and 3 (each within the scatter of the next); then compounds 2 and 4 (each within the scatter of the next).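

In this assay, for the compounds shown here, the step of a 1.6-fold higher number from compound 2 to compound 4 (0.20 log units; within the scatter) is the first measured exchange of one whole aryl group for another at this place. It shows that 5-fluoro-2-methylphenyl and 2-(trifluoromethyl)phenyl cannot be told apart by this read-out on this core, although the entering group has more heavy atoms. No evidence is available that would explain this result. From the compounds shown here alone, whether an aryl group carrying an amine or a carboxylic acid would give a different number here remains open. So does whether 2-(trifluoromethyl)phenyl would read the same on the core of compound 1.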